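A fluoro on the phenyl ring of compound 3

This account rests on a few compounds, and the source may have more. Where it says the series, first, only, none or still open, it means among the compounds named here.

Going by the values given here, compound 3 `COc1cc2c(Oc3ccc(NC(=O)c4cc(-c5ccccc5)ccn4)cc3F)ccnc2cc1OCCCN1CCCC1` stands second highest of the three numbers so far in a functional assay on NCI-H460 cells (Homo sapiens) for cytotoxicity, read by MTT assay, with a stated time of 72 h; on this read-out higher numbers stand for weaker inhibition and lower numbers for stronger inhibition; compound 3 gives 130 nM. Compound 1 `COc1cc2c(Oc3ccc(NC(=O)c4cc(-c5ccccc5)ccn4)cc3F)ccnc2cc1OCCCN1CCN(C)CC1` gives 91 nM, and the step of a 1.4-fold higher number from compound 1 to compound 3 (0.15 log units; within the scatter) lies within the scatter. Among the compounds with values here, compound 2 `COc1ccc(-c2ccnc(C(=O)Nc3ccc(Oc4ccnc5cc(OCCCN6CCN(C)CC6)c(OC)cc45)c(F)c3)c2)c(OC)c1` gives 430 nM, and the step of a 4.7-fold higher number from compound 1 to compound 2 (0.67 log units; beyond the scatter) is the only change on the phenyl ring measured here.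

Compound 4 `COc1cc2c(Oc3ccc(NC(=O)c4cc(-c5ccccc5F)ccn4)cc3F)ccnc2cc1OCCCN1CCCC1` differs from compound 3 by fluoro in place of hydrogen on an aromatic carbon. Within the data shown here, the one measured step that bears on this ring is a 4.7-fold higher number from compound 1 to compound 2 (0.67 log units; beyond the scatter), a modest weakening from a far larger change at the same place, 2,4-dimethoxyphenyl in place of phenyl. Among the measured compounds shown here, a single fluoro ortho to the large group is a much smaller change, and no measured pair tests it directly. The step of a 1.4-fold higher number from compound 1 to compound 3 (0.15 log units; within the scatter) only fixes where compound 3 stands. The expectation is therefore a step of a 1.2-fold higher number from compound 3 to compound 4 (0.09 log units; within the scatter) that stays within or only just beyond the scatter, leaning weaker if anything. Compound 4 is estimated at 160 nM, with a range of 70 nM to 400 nM.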

Compound 4, half-maximal inhibitory concentration: 140 nM
Compound 4: the middle estimate sits 1.1-fold (0.06 log units) above what was measured; low and high end bracket the measured number.
By their numbers in this assay, from the lowest: compounds 1, 3 and 4 (each within the scatter of the next); then compound 2.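

In this assay, the step to the 2-fluorophenyl group, a 1.1-fold higher number from compound 3 to compound 4 (0.03 log units; within the scatter), shows that this position accepts a fluoro ortho to a large group with no change that can be told from the scatter. Going by these compounds alone, the only earlier change on this ring, a 4.7-fold higher number from compound 1 to compound 2 (0.67 log units; beyond the scatter), lies beyond the scatter, so the ring is now known to give both kinds of outcome, depending on what enters. No measurement shown offers a reason for either outcome.

The compounds shown leave open whether a chloro, a trifluoromethyl or a single methoxy at this same place would also stay within the scatter of compound 3. They also leave open whether fluoro would read the same alongside the 4-methylpiperazin-1-yl group of compound 1.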